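The source may report more compounds than this note shows. Statements on the series, on what has been measured and on what is new or still open speak of the compounds shown alone.

The measured compounds, each with its number in a functional assay on HepG2 cells (Homo sapiens) for cytotoxicity, read by MTT assay, with a stated time of 24 h; on this read-out lower numbers stand for stronger inhibition and higher numbers for weaker inhibition:

compound 1, `CN(C)CCN1CCN(CC(=O)Nc2ccc(-c3nc4ccccc4o3)cc2)CC1`, 16300 nM;
compound 2, `Cc1cc(-c2nc3cc(F)ccc3o2)ccc1NC(=O)CCl`, 16600 nM;
compound 3, `CN(C)CCN1CCN(CC(=O)Nc2ccc(-c3nc4cc(F)ccc4o3)cc2)CC1`, 18800 nM.

Compounds 1 and 3 share one core and differ in a single place: compound 1 carries hydrogen in place of fluoro on an aromatic carbon. In this assay this gave a 1.2-fold lower number from compound 3 to compound 1 (0.06 log units; within the scatter), so the two numbers cannot be told apart. Compound 2 is built on a different core, and the difference between the two cores is not broken down here; its value stands close to both of the others, all three within the scatter of one another.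

Compound 4, `Cc1cc(-c2nc3ccccc3o2)ccc1NC(=O)CCl`, has not yet been measured in this assay. Going by the values given here, it differs from compound 2 by hydrogen in place of fluoro on an aromatic carbon, which is the same change, at the same place, as the one from compound 3 to compound 1. Because that earlier step was a 1.2-fold lower number from compound 3 to compound 1 (0.06 log units; within the scatter), a step of similar small size is expected here. Compound 4 is therefore estimated at 15000 nM, with an expected range from 8000 nM to 30000 nM. This means an expected step of a 1.1-fold lower number from compound 2 to compound 4 (0.04 log units; within the scatter).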

Compound 4, half-maximal inhibitory concentration: 14800 nM
Compound 4: middle estimate off by 1.0-fold (0.01 log units), on the high side; low and high end bracket the measured number.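

In this assay, hydrogen in place of fluoro on the core of compound 2 gave a 1.1-fold lower number from compound 2 to compound 4 (0.05 log units; within the scatter), so the two numbers cannot be told apart. Set beside the earlier step, the change reads alike on both cores: the same change on two cores in this assay, a 1.2-fold lower number (0.06 log units; within the scatter) from compound 3 to compound 1 and a 1.1-fold lower number (0.05 log units; within the scatter) from compound 2 to compound 4, 1.0-fold (0.01 log units) apart, within the scatter of two such steps. This shows that, in this small set, carrying the change from one core to the other left the number within the scatter both times, but it does not show that the fluoro matters or does not matter in general, and two pairs that each stay within the scatter cannot show how a change of readable size would carry across cores.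

The compounds shown leave open whether a different group at this place, such as chloro, methoxy or an amine, would move the number beyond the scatter. They also leave open whether hydrogen in place of fluoro would read the same on another aromatic carbon or on a third core.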